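The source may report more compounds than this note shows. Statements on the series, on what has been measured and on what is new or still open speak of the compounds shown alone.

Of the compounds shown here, two built on one shared core have been measured in an assay on CHO cells for displacement of a labelled ligand from adenosine receptor A1 (Homo sapiens), tested at 10 uM (on this read-out higher numbers stand for more inhibition at the one concentration tested (going by the name of the read-out) and lower numbers for less inhibition), so far. Compound 1 `CC(=O)Nc1nn(-c2ccccc2)c(=O)c2ccccc12` carries a methyl on the carbonyl carbon of its amide, and in this assay compound 1 gives 52% at the tested concentration. Compound 2 `O=C(Nc1nn(-c2ccccc2)c(=O)c2ccccc12)c1ccccc1` carries a phenyl on that carbonyl carbon instead, and in this assay compound 2 gives 44% at the same concentration. Swapping phenyl for methyl on a carbonyl carbon brought a number 8 percentage points lower from compound 1 to compound 2 (within the scatter) and so the two numbers cannot be told apart. Among the two numbers available, compound 2 holds the lower one, yet its gap to compound 1 sits within the scatter of repeated measurements.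

Compound 3 `O=C(Nc1ccccc1Cl)Nc1nn(-c2ccccc2)c(=O)c2ccccc12` has not yet been measured. It differs from compound 2 in one place: (2-chlorophenyl)amino in place of phenyl on a carbonyl carbon. Going by the values given here, the only measured step, the exchange of methyl for phenyl on the same carbonyl carbon, was small and within the scatter, and no measured step exchanges an aryl group for an arylamino group, so there is no direct guide for this change. The expected step is therefore about a number 1 percentage points higher from compound 2 to compound 3 (within the scatter) and so no change beyond the scatter. Compound 3 is estimated to give 45% in this assay, with a range from 20% to 70% covering most repeats.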

Compound 3, a percentage reported as inhibition, at one concentration (the size of the read-out at that concentration, not a potency): 0%
Compound 3: middle estimate off by 45 percentage points, on the high side, outside the stated range (below it).
By their numbers in this assay, from the lowest: compound 3; then compounds 2 and 1 (each within the scatter of the next).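

The group on this carbonyl carbon is not indifferent in this assay: methyl and phenyl could not be told apart, yet (2-chlorophenyl)amino gives a number 44 percentage points lower from compound 2 to compound 3 (beyond the scatter) and, set against the methyl amide, a number 52 percentage points lower from compound 1 to compound 3 (beyond the scatter). So one exchange at this position leaves the two numbers within the scatter of each other, while another exchange at the same place brings a lower number in this assay, beyond the scatter. The entering group keeps the six-membered aromatic ring of phenyl but adds a nitrogen with its hydrogen-bond donor and a chlorine, and nothing available shows which of these additions goes with the drop or why it occurs.

The compounds shown change the nitrogen and the chlorine together, so a plain phenylamino group, without the chlorine, would be needed to tell their contributions apart. On these data alone, a small methylamino group or a methoxy group on the same carbonyl carbon would also be informative, since it remains open whether the loss extends beyond this one aromatic group.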